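Lipophilicity notes on the pyridinone amide series

A few compounds are considered here, and "the series" means these few. Any claim that something is new, unique, unknown or untested is made for them only; others in the source may bear on it.

Of the compounds shown here, two of the shared core have been measured in a physicochemical assay for lipophilicity, at pH 7.4; a lower number here means a more polar compound, a higher number a more lipophilic compound. Compound 1 `CNC(=O)c1cccn(Cc2ccccc2)c1=O` gives 3, the highest of the two numbers. Compound 2 `CNC(=O)c1cc(C(=O)NC2CC2)cn(CC2CCOCC2)c1=O` differs from compound 1 in several places. In this assay compound 2 gives 1.5, a number lower than that of compound 1, beyond the scatter.

Compound 3 `CNC(=O)c1cc(C(=O)NCCOC)cn(Cc2ccccc2)c1=O` has not yet been measured in this assay. Relative to compound 1 it carries (2-methoxyethyl)carbamoyl in place of hydrogen on an aromatic carbon, placed on an aromatic carbon of a six-membered aromatic ring with one nitrogen, two atoms from the ring nitrogen. Going by the values given here, no single-change step between measured compounds is available as a guide. Given that compound 2, which also carries a carbamoyl group at that place, stands at 1.5, a downward step of moderate size is expected for compound 3, a number 1.00 log units lower from compound 1 to compound 3 (beyond the scatter), beyond the scatter. Compound 3 is therefore estimated at 2, with a range from 1.5 to 2.6.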

Compound 3, distribution coefficient: 2.7
Estimate against measurement, compound 3: 0.70 log units below; the measured number lies above the stated range.
By their numbers in this assay, from the lowest: compound 2; then compounds 3 and 1 (each within the scatter of the next).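

Working notes, position two atoms from the ring nitrogen: this is the first single-change step at this place, and in this assay (2-methoxyethyl)carbamoyl in place of hydrogen on an aromatic carbon gives a number 0.30 log units lower from compound 1 to compound 3 (within the scatter). With this side chain, then, the added carbamoyl leaves the number of the core of compound 1 within the scatter, and the step gives no support for assigning the value of compound 2 to a carbamoyl group at this place alone. Nothing on hand explains this result.

Open, from the compounds shown here alone, is whether a carbamoyl group bearing an amine or a carboxylic acid on its chain, or a cyclopropyl group as in compound 2, would also stay within the scatter at this place. Also open, going by these compounds, is what a change of the benzyl group alone would do in this assay, on either compound 1 or compound 3.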